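The compounds below may be only part of what the source reports. "The series", "measured", "known", "first", "only" and "open" are said of these compounds alone.

Measured so far:
Compound 1 `O=C(O)CC1COc2cc(OCc3nc(-c4ccccc4)cs3)ccc21`, which in a functional assay on CHO cells for agonist activity at Free fatty acid receptor 1 (Homo sapiens), read by FLIPR and calcium flux, tested at 100 nM (on this read-out higher numbers stand for a stronger effect at the one concentration tested and lower numbers for a weaker effect), gives 0.16%.
Compound 2 `Cc1nc(-c2ccc(Cl)s2)sc1COc1ccc2c(c1)OCC2CC(=O)O`, which in this assay gives 8.34%.
Compound 3 `Cc1ccccc1-c1nc(C)c(COc2ccc3c(c2)OCC3CC(=O)O)s1`, which in this assay gives 10.7%.

All three share the same acid-bearing core and differ only in the aromatic group hanging off the thiazole. Compound 3 stands beyond the usual scatter above compound 1, while its gap to compound 2 is within the scatter, so compound 3 and compound 2 cannot be told apart on these numbers. Among the compounds with values here, the one measured step, a number 2.4 percentage points higher from compound 2 to compound 3 (within the scatter), swapped the whole aryl group and stayed within the scatter.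

Compound 4 `Cc1nc(-c2ccccc2F)sc1COc1ccc2c(c1)OCC2CC(=O)O` differs from compound 3 in a single place: fluoro in place of methyl on an aromatic carbon. Within the data shown here, no measured step touches this kind of change, and the only step available, from one aryl group to another, was small. For compound 4 the expectation is therefore a step of about a number 2.7 percentage points lower from compound 3 to compound 4 (within the scatter) in this assay, which is within the scatter, with the estimate for compound 4 at 8%, between 0% and 20%.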

Compound 4, a percentage reported as activity, at one concentration (the size of the read-out at that concentration, not a potency): 25.8%
The estimate for compound 4 lay 17.8 percentage points below the measured number; measured number above the stated range.
By their numbers in this assay, from the lowest: compounds 1, 2 and 3 (each within the scatter of the next, the first and the last beyond it); then compound 4.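

Fluoro in place of methyl gives a number 15.1 percentage points higher from compound 3 to compound 4 (beyond the scatter) in this assay and shows that a single heavy atom at this place, ortho to a large group, can matter. That is more than the earlier exchange of one whole aromatic group for another revealed, since it stayed within the scatter. 2-Fluorophenyl in place of 5-chlorothiophen-2-yl gives a number 17.5 percentage points higher from compound 2 to compound 4 (beyond the scatter) as well, so 2-fluorophenyl stands clearly above both of the other groups tried on this core, and nothing shown here offers a reason for this.

From the compounds shown here alone, whether the gain belongs to fluoro alone stays open, and chloro, methoxy or a nitrile at the same place would help to settle that. Going by these compounds, the read-out also comes from one concentration, so how these compounds would rank across a range of concentrations remains unknown.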